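The source may report more compounds than this note shows. Statements on the series, on what has been measured and on what is new or still open speak of the compounds shown alone.

Of the compounds shown here, three have been measured in an assay for inhibition of histone-lysine N-methyltransferase, H3 lysine-79 specific (Homo sapiens), read by scintillation counting, with stated times of 15 min and 60 min, tested at 100 uM, in the presence of a further agent that is not named here; on this read-out lower numbers stand for a weaker effect and higher numbers for a stronger effect at the one concentration tested. Compound 1 `Cc1occc1-c1nnc2sc(Cc3ccccc3)nn12` gives 24%. Compound 3 `Cc1occc1-c1nnc2sc(CCc3ccccc3)nn12` gives 27%, and the step of a number 3 percentage points higher from compound 1 to compound 3 (within the scatter). Compound 2 `Fc1cccc(-c2nnc3sc(/C=C/c4ccco4)nn23)c1` gives 29%, the highest of the three numbers, but both compound 3 and compound 1 lie within the scatter of it, so no order among the three can be read from these numbers.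

Compound 4 `Fc1ccc(-c2nnc3sc(/C=C/c4ccco4)nn23)cc1` has not yet been measured. It differs from compound 2 in one place: 4-fluorophenyl in place of 3-fluorophenyl on an aromatic carbon. For the measured compounds named here, no measured step bears on this change: the single step available, from compound 1 to compound 3, concerns a saturated chain carbon rather than the aromatic carbon in question, and it stayed within the scatter. There is thus no measured guide to the exchange of 3-fluorophenyl for 4-fluorophenyl, and the working assumption is no step beyond the scatter. Compound 4 is expected to give about 29%, with a range from 15% to 43%. The expected step is accordingly no change at the digits printed from compound 2 to compound 4 (within the scatter), which is taken to lie within the scatter.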

Compound 4, a percentage reported as inhibition, at one concentration (the size of the read-out at that concentration, not a potency): 40%
Compound 4: the middle estimate sits 11 percentage points below what was measured, within the range that was stated.
By their numbers in this assay, from the lowest: compounds 1, 3 and 2 (each within the scatter of the next); then compound 4.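

In this assay, for the compounds shown here, the exchange of 3-fluorophenyl for 4-fluorophenyl on the aromatic carbon gives a number 11 percentage points higher from compound 2 to compound 4 (beyond the scatter), the first step that lies beyond the scatter. The two groups have the same atoms, joined differently, so this place responds to how the group is joined and not only to which atoms it contains. No evidence on the origin of this step is available.

The compounds shown leave open how an unsubstituted phenyl, a 4-chlorophenyl or a 4-methoxyphenyl would read at this place. They also leave open whether the step from 3-fluorophenyl to 4-fluorophenyl would recur with the other side of the shared core changed, and, since each number comes from a single concentration, whether it would carry over to a potency.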